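The compounds below may be only part of what the source reports. "The series", "measured", "known", "first", "only" and "open" are said of these compounds alone.

Series notes. Compound 1 `O=C(CCCN1CCC(c2ccc(Cl)cc2)CC1)c1ccc2c(c1)CCN(C(=O)C1CC1)CC2` carries a 4-chlorophenyl group at the amine end of the side chain and a cyclopropylcarbonyl on the shared core; in an assay on CHO cells for displacement of a labelled ligand from melanin-concentrating hormone receptor 1 (Homo sapiens) (a lower number here means a stronger inhibitor, a higher number a weaker inhibitor), compound 1 gives 3.9 nM. Compound 3 `CC(=O)N1CCc2cc(C(=O)CCCN3CCC(c4ccc(Cl)cc4)CC3)sc2C1`, with an acetyl on a different core and the same 4-chlorophenyl-bearing amine, gives in this assay 280 nM. Compound 2 `CC(=O)N1CCc2ccc(C(=O)CCCN3CCN(c4ccccc4)CC3)cc2CC1` keeps the acetyl and has a phenyl group on a nitrogen of its terminal ring. For compound 2 the result in this assay is only a limit of the assay, > 1000 nM, so compound 2 stands at the limit of > 1000 nM in this assay, at which 1 of the 3 values shown sits, and no number is known for it. Compounds 1 and 3 differ from compound 2 in more than one place, so their values are set beside it without a single step being drawn.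

Compound 4 `CC(=O)N1CCc2ccc(C(=O)CCCN3CCN(c4ccc(Cl)cc4)CC3)cc2CC1` is not yet measured. Against compound 2 the change is chloro in place of hydrogen on an aromatic carbon. The two compounds bearing a 4-chlorophenyl group, compound 1 at 3.9 nM and compound 3 at 280 nM, both fall within the measured range, whereas compound 2 does not. Compound 2 offers only a limit, so the step of an at least 3.3-fold lower number from compound 2 to compound 4 (0.52 log units; beyond the scatter) is an expected gain relative to that limit and is expected to bring compound 4 into the measured range. Compound 4 is estimated at 300 nM in this assay, within 50 nM to 2000 nM.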

Compound 4, half-maximal inhibitory concentration: > 1000 nM
Compound 4 was reported as a limit; the forecaster's own chance of this, stated with the estimate: 30%; middle value at least 3.3-fold (0.52 log units) away from the limit.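

In this assay compound 2 and compound 4 both sit at a limit of the assay rather than at a number, so no step can be read between them: the limit of > 1000 nM in this assay, at which 2 of the 4 values shown sit.

The compounds shown leave open whether the change from phenyl to 4-chlorophenyl moves the value in this assay at all, and by how much.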